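Fluoro to Methoxy on the Benzyl Ring

This account rests on a few compounds, and the source may have more. Where it says the series, first, only, none or still open, it means among the compounds named here.

Measured so far in a functional assay on NCI-H522 cells (Homo sapiens) for inhibition, read by sulforhodamine B assay, with a stated time of 48 h; a lower number here means that less compound is tolerated, a higher number that more compound is tolerated:
Compound 1, `Nc1cc(N)c2nc(-c3ccccc3)c(NCc3ccc(Cl)c(Cl)c3)nc2c1`, gives 22400 nM.
Compound 2, `Nc1cc(N)c2nc(-c3ccccc3)c(NCc3ccc(F)cc3)nc2c1`, gives only a limit of the assay, < 100000 nM.

Going by the values given here, compound 2 thus stands at a limit rather than at a number, the one value that sits at the limit of < 100000 nM in this assay, at which 1 of the 2 values shown sits. Among the compounds with values here, the only measured step, a step that the limit leaves unreadable from compound 1 to compound 2, therefore cannot be read in size or direction. Compound 3, `COc1ccc(CNc2nc3cc(N)cc(N)c3nc2-c2ccccc2)cc1`, differs from compound 2 by methoxy in place of fluoro on an aromatic carbon. Within the data shown here, no measured step touches a methoxy group, and the one step at this position is unreadable, so nothing points to a move beyond the scatter; the expected step is a step that the limit leaves unreadable from compound 2 to compound 3. Compound 3 is therefore estimated at 30000 nM in this assay, within a wide range from 8000 nM to 100000 nM, and a reading that is again only a limit remains quite possible.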

Compound 3, concentration lethal to 50% of the cells: 47900 nM
Beside the measured number, compound 3's estimate is 1.6-fold (0.20 log units) below it; the measured number falls inside the stated range.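

In this assay, the position carrying the substituted benzyl group now has its first readable step: a 2.1-fold higher number from compound 1 to compound 3 (0.33 log units; beyond the scatter). This step is modest, and it shows that a change at this position can move the number beyond the scatter, with 4-methoxyphenyl and 3,4-dichlorophenyl as the two groups compared. The steps that run through compound 2, including fluoro to methoxy itself, cannot be read, since compound 2 stands only at a limit: the limit of < 100000 nM in this assay, at which 1 of the 3 values shown sits.

The compounds shown leave open whether a single chlorine, as in a 4-chlorophenyl group, would give a number closer to that of compound 1 or of compound 3. They also leave open how a hydroxyl or a dimethylamino group on this ring, or a longer chain on the nitrogen, would read.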